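The source may report more compounds than this note shows. Statements on the series, on what has been measured and on what is new or still open speak of the compounds shown alone.

Measured so far in an ADME assay on Huh-7 cells (Homo sapiens) for cytotoxicity, with a stated time of 72 h; a lower number here means that less compound is tolerated, a higher number that more compound is tolerated:
Compound 1 `CCOc1cccc2c1S(=O)(=O)N=C2C1=C(O)[C@H](C(C)C)N(CCC(C)(C)C)C1=O`: > 33000 nM
Compound 2 `CCOc1cccc2c1S(=O)(=O)N=C2C1=C(O)[C@H](C(C)(C)C)N(CCC(C)(C)C)C1=O`: > 33000 nM
Compound 3 `CCOc1cccc2c1S(=O)(=O)N=C2C1=C(O)[C@H](CC(C)C)N(CCC(C)(C)C)C1=O`: > 33000 nM

Each of these entries is a limit of the assay and not a number. Compound 2 therefore has no exact place among the three, and its entry of > 33000 nM is a limit too.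

Compound 4 `CC(C)(C)CCN1C(=O)C(C2=NS(=O)(=O)c3c(OCc4ncon4)cccc32)=C(O)[C@@H]1C(C)(C)C` differs from compound 2 by one change: 1,2,4-oxadiazol-3-yl in place of methyl on a saturated chain carbon bound to an oxygen on an aromatic ring. Three measured steps are available: a step that the two limits leave unreadable from compound 1 to compound 2, a step that the two limits leave unreadable from compound 1 to compound 3 and a step that the two limits leave unreadable from compound 2 to compound 3. None of them alters the chain carbon bound to an oxygen on an aromatic ring, and none has a readable size. All that the series offers is the limit of > 33000 nM in this assay, at which 3 of the 3 values shown sit. No step beyond the usual scatter is therefore expected, though a number could appear only on the lower side of that limit. The expected change is an at least 1.1-fold lower number from compound 2 to compound 4 (0.04 log units; that floor lies within the scatter). For compound 4 the estimate is 30000 nM, with an expected range from 14000 nM to 33000 nM.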

Compound 4, half-maximal cytotoxic concentration: > 33000 nM
Compound 4 was reported as a limit (the forecaster's own chance of this, stated with the estimate: 70%); middle value at least 1.1-fold (0.04 log units) from the limit.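

In this assay compound 4 gives > 33000 nM as a limit of the assay and not a number, so the step from compound 2 to compound 4 cannot be read. The compounds shown leave open the concentration at which any of them harms these cells: the limit of > 33000 nM in this assay, at which 4 of the 4 values shown sit.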